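Inverting one stereocentre of compound 1

The source may report more compounds than this note shows. Statements on the series, on what has been measured and on what is new or still open speak of the compounds shown alone.

Of the compounds shown here, two have been measured so far in a functional assay on LoVo cells (Homo sapiens) for cytotoxicity, read by CCK-8 assay, with a stated time of 14 h; a lower number here means a stronger inhibitor, a higher number a weaker inhibitor. Compound 1 `CC(=O)OC[C@H]1O[C@@H](S[C@H]2CC(=O)[C@@H]3OC[C@H]2O3)[C@H](OC(C)=O)[C@@H](OC(C)=O)[C@@H]1OC(C)=O` gives 166000 nM, the lower of the two numbers. Compound 2 `O=C(O)c1ccccc1S[C@H]1CC(=O)[C@@H]2OC[C@H]1O2` gives 641000 nM, and the gap between them lies beyond the scatter. Compound 1 is the better-placed reference only by this one comparison.

The next compound is compound 3 `CC(=O)OC[C@H]1O[C@@H](S[C@H]2CC(=O)[C@@H]3OC[C@H]2O3)[C@H](OC(C)=O)[C@@H](OC(C)=O)[C@H]1OC(C)=O`, which keeps all the atoms and bonds of compound 1. The change is the two compounds have the same atoms and bonds and differ only in configuration as drawn: 1 of 8 stereo elements differ; a stereocentre at a saturated ring carbon is drawn R in compound 1 and S in compound 3. Nothing leaves and nothing enters.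

Among the measured compounds shown here, no measured pair isolates a change of configuration, so the data offer no direct guide to its size or direction. For the measured compounds named here, with only this evidence, no step beyond the scatter is expected in this assay, and a slight rise in the number is the tentative expectation. The estimated step of a 1.2-fold higher number from compound 1 to compound 3 (0.08 log units; within the scatter) remains an expectation until measured. For compound 3 the estimated value is 200000 nM, with an expected range from 90000 nM to 450000 nM.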

Compound 3, half-maximal inhibitory concentration: 624000 nM
Compound 3: middle estimate off by 3.1-fold (0.49 log units), on the low side, outside the stated range (above it).
By their numbers in this assay, from the lowest: compound 1; then compounds 3 and 2 (each within the scatter of the next).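

In this assay, inverting this saturated ring carbon gives a 3.8-fold higher number from compound 1 to compound 3 (0.58 log units; beyond the scatter), so the configuration at this one centre is enough to move the number beyond the scatter. Among the compounds shown here, this is the first measured pair to isolate configuration, and it shows that the position is sensitive to its three-dimensional arrangement even when no atom leaves or enters, with the R configuration as drawn giving the lower number of the two. The step can be assigned to this single stereocentre because the pair offers no other difference: the fact that compounds 1 and 3 differ only in the configuration as drawn

One pair at one centre leaves open whether the other stereo elements of the structure matter to a similar extent, and whether the same direction would hold on a different substituent set or in another cell line. From the compounds shown here alone, it is also open whether replacing the ester substituent at this carbon with an amine or a longer chain would keep the difference between the two configurations, and whether any such change would bring the number lower than that of compound 1.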